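Hydroxy removal in a trimethylpyrazine cinnamate ester pair

The compounds below may be only part of what the source reports. "The series", "measured", "known", "first", "only" and "open" are said of these compounds alone.

Two esters of the shared core have been measured in a functional assay on EA.hy 926 cells (Homo sapiens) for cytotoxicity, read by MTT assay, with stated times of 24 h and 12 h; a lower number here means that less compound is needed, a higher number that more compound is needed for the effect. Compound 1 `Cc1nc(C)c(C(=O)Oc2ccc(/C=C/C(=O)O)cc2O)nc1C` gives 2200 nM and holds the lowest number of the two. Among the measured compounds shown here, compound 2 `Cc1nc(C)c(C(=O)Oc2ccccc2/C=C/C(=O)O)nc1C` gives 36700 nM in this assay, a gap to compound 1 that lies beyond the usual scatter; the two differ in where the 2-carboxyethenyl group sits relative to the ester, and no single-point step between them is recorded, so only their two values are stated here.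

Compound 3 `Cc1nc(C)c(C(=O)Oc2ccc(/C=C/C(=O)O)cc2)nc1C` is not yet measured in this assay. It differs from compound 1 by hydrogen in place of hydroxy on an aromatic carbon, at a carbon ortho to a large group and meta to the 2-carboxyethenyl group. For the measured compounds named here, no step of this kind exists among the measured compounds, so the expectation rests on the standing of compound 1 alone. The expected step from compound 1 to compound 3 is a 2.3-fold higher number from compound 1 to compound 3 (0.36 log units; beyond the scatter), a moderate rise in the number, with a wide spread that also allows a change no larger than the scatter. Compound 3 is therefore estimated at 5000 nM, within 1500 nM to 18000 nM.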

Compound 3, half-maximal effective concentration: 38000 nM
For compound 3 the middle estimate is 7.6-fold (0.88 log units) below the measured one, outside the stated range (above it).
By their numbers in this assay, from the lowest: compound 1; then compounds 2 and 3 (each within the scatter of the next).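

In this assay, among the compounds shown here, hydrogen in place of hydroxy on the aromatic carbon ortho to a large group and meta to the 2-carboxyethenyl group gives a 17-fold higher number from compound 1 to compound 3 (1.24 log units; beyond the scatter), the first step that can be read as a change in one place. The lowest number among the three compounds therefore goes with this hydroxy, and the shared core carrying the ester and the 2-carboxyethenyl group does not reach that number without it. Nothing at hand bears on the reason for the size of this step.

As far as these compounds go, it remains open whether the step belongs to hydroxy specifically or whether another group on this same carbon, such as methoxy, an amine or fluorine, would hold the number of compound 1. Also open, from the compounds shown here alone, is whether the step depends on the rest of compound 1, for instance whether it would persist with the methyl ester in place of the carboxylic acid, or whether a hydroxy added to compound 2 would give a step of similar size.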